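The compounds below may be only part of what the source reports. "The series", "measured", "known", "first", "only" and "open" are said of these compounds alone.

Working notes on the series. In an ADME assay on the whole organism (Rattus norvegicus, strain Sprague-Dawley) for metabolic stability, read by LC-MS, with stated times of 5 min and 24 h, at a dose of 5 mg/kg by the oral route (on this read-out lower numbers stand for a shorter-lived compound and higher numbers for a longer-lived compound), compound 1 `N#Cc1cnc(NC(=O)N2CCCc3cc(CN4CCOCC4=O)c(C=O)nc32)cc1S[C@H]1CCOC1` gives 0.79 h, compound 3 `N#Cc1cnc(NC(=O)N2CCCc3cc(CN4CCOCC4=O)c(C=O)nc32)cc1S[C@@H]1CCOC1` gives 0.96 h and compound 2 `COCCNc1cc(NC(=O)N2CCCc3cc(CN4CC[C@H](OC)C4=O)c(C=O)nc32)ncc1C#N` gives 1 h. Compound 2 therefore stands level with the other two, with both gaps inside the scatter.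

The next compound to read is compound 4 `COCCNc1cc(NC(=O)N2CCCc3cc(CN4CC[C@@H](OC)C4=O)c(C=O)nc32)ncc1C#N`, the partner of compound 2: the two compounds have the same atoms and bonds and differ only in configuration as drawn: 1 of 1 stereo elements differ; a stereocentre at a saturated ring carbon is drawn S in compound 2 and R in compound 4.

One measured step is of the same kind: a 1.2-fold higher number from compound 1 to compound 3 (0.08 log units; within the scatter). It bears on this case through (the fact that compounds 1 and 3 differ only in the configuration as drawn). Going by the values given here, it concerns a different stereocentre, so it serves only as a guide, and it is the single such pair with numbers on both sides. On that evidence, no step beyond the scatter is expected in this assay, and no direction is favoured.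

The expected step is no change at the digits printed from compound 2 to compound 4 (within the scatter). For compound 4 the estimated half-life is 1 h, with an expected range of 0.55 h to 1.8 h.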

Compound 4, half-life: 1.1 h
The estimate for compound 4 lay 1.1-fold (0.04 log units) below the measured number, within the range that was stated.
By their numbers in this assay, from the lowest: compounds 1, 3, 2 and 4 (each within the scatter of the next).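

In this assay the configuration at this saturated ring carbon now has numbers on both sides, and the result is a 1.1-fold higher number from compound 2 to compound 4 (0.04 log units; within the scatter). The earlier pair spoke only to a different stereocentre, so this pair alone speaks to this one, and it reads as a pure change of configuration because nothing else separates the two compounds: the fact that compounds 2 and 4 differ only in the configuration as drawn. Together with a 1.2-fold higher number from compound 1 to compound 3 (0.08 log units; within the scatter), it gives two pairs in the series, at two different stereocentres, and neither shows a step beyond the scatter.

Still open, on these data alone, is whether replacing the group on this ring carbon with a primary amine or a carboxylic acid would give a step beyond the scatter in this assay. Also open, as far as these compounds go, is whether either stereocentre matters in any other read-out.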